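A few compounds are considered here, and "the series" means these few. Any claim that something is new, unique, unknown or untested is made for them only; others in the source may bear on it.

Measured so far:
- compound 1 `CCSCCn1c(N2CCN(C)CC2)nc2ccccc21`: 19 nM
- compound 2 `CCCCCCCCCCn1c(N2CCN(C)CC2)nc2ccccc21`: 4200 nM

In a functional assay on ileum for inhibition of histamine H1 receptor (Cavia porcellus) (on this read-out lower numbers stand for stronger inhibition and higher numbers for weaker inhibition), compound 2 stands highest of the two numbers, its nearest neighbour being compound 1 at 19 nM. Compound 3 `CCSCCCn1c(N2CCN(C)CC2)nc2ccccc21` differs from compound 2 by ethylsulfanyl in place of heptyl on a saturated chain carbon, three bonds along the chain from an aromatic nitrogen. Among the compounds with values here, the one step that bears on this is the reverse of it in kind: a 220-fold higher number from compound 1 to compound 2 (2.34 log units; beyond the scatter). Undoing most of that change in compound 3 is therefore expected to give a large step down in this assay, estimated as a 110-fold lower number from compound 2 to compound 3 (2.02 log units; beyond the scatter). For compound 3 the expected value is 40 nM, with a range from 10 nM to 200 nM.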

Compound 3, half-maximal inhibitory concentration: 530 nM
For compound 3 the middle estimate is 13-fold (1.12 log units) below the measured one; the whole stated range lies below it.
By their numbers in this assay, from the lowest: compound 1; then compound 3; then compound 2.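

Replacing heptyl with ethylsulfanyl in this assay gives a 7.9-fold lower number from compound 2 to compound 3 (0.90 log units; beyond the scatter), so this sulfur-containing chain recovers only part of the ground lost with the octyl group of compound 2. The position of the sulfur also counts, since (ethylsulfanyl)methyl in place of ethylsulfanyl gives a 28-fold higher number from compound 1 to compound 3 (1.45 log units; beyond the scatter), even though both chains contain the same ethylsulfanyl group. Nothing available explains why these chains differ.

As far as these compounds go, whether an ether oxygen or an amine in place of the sulfur would follow the same trend remains open. So does the effect of a longer chain carrying ethylsulfanyl.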